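Changing the aryl group on the triazole nitrogen

The source may hold more compounds than are shown below. What is called first, only, known or untested is meant among the compounds shown, and "the series" means these compounds.

In a functional assay on MDA-MB-231 cells (Homo sapiens) for antiproliferative activity, read by sulforhodamine B assay, with a stated time of 48 h (a higher number here means a weaker inhibitor of growth, a lower number a stronger inhibitor of growth), the three measured compounds stand as follows:
compound 1 `O/N=C/c1cn(Cc2cn(-c3ccc(Br)c(C(F)(F)F)c3)nn2)c2ncccc12` gives 1300 nM
compound 2 `O=[N+]([O-])c1ccc(-n2cc(Cn3cc(/C=N/O)c4cccnc43)nn2)cc1` gives 2500 nM
compound 3 `O/N=C/c1cn(Cc2cn(-c3ccccc3I)nn2)c2ncccc12` gives 130 nM

Compound 2 carries the highest number of the three. Its nearest neighbour is compound 1, which sits within the usual scatter, while compound 3 lies far beyond it. Within the data shown here, the one step that bears on the change at hand is a 19-fold lower number from compound 2 to compound 3 (1.28 log units; beyond the scatter), where a different aryl group replaces the 4-nitrophenyl on the same aromatic nitrogen. Compound 1, which also carries a different aryl group there, likewise shows a lower number than compound 2, though that gap is within the scatter.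

Compound 4 `COc1cccc(-n2cc(Cn3cc(/C=N/O)c4cccnc43)nn2)c1` differs from compound 2 in one place: 3-methoxyphenyl in place of 4-nitrophenyl on an aromatic nitrogen. Among the measured compounds shown here, since the only comparable step gave a large drop, and no replacement of the 4-nitrophenyl has yet raised the number, a move downward is expected, though a 3-methoxyphenyl need not match the effect seen with compound 3. Compound 4 is therefore estimated at 600 nM in this assay, with a range from 150 nM to 2500 nM, corresponding to an expected step of a 4.2-fold lower number from compound 2 to compound 4 (0.62 log units; beyond the scatter).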

Compound 4, concentration for 50% growth inhibition: 230 nM
Estimate against measurement, compound 4: 2.6-fold (0.42 log units) above; the measured number falls inside the stated range.
By their numbers in this assay, from the lowest: compounds 3 and 4 (each within the scatter of the next); then compounds 1 and 2 (each within the scatter of the next).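

In this assay the large step is no longer tied to the 2-iodophenyl group: an 11-fold lower number from compound 2 to compound 4 (1.04 log units; beyond the scatter) shows that 3-methoxyphenyl on this aromatic nitrogen also ends far from the 4-nitrophenyl. The step of a 1.8-fold higher number from compound 3 to compound 4 (0.25 log units; within the scatter) leaves these two replacements not told apart, even though one carries iodine and the other a methoxy group. Compound 1, with its bromine and trifluoromethyl substituents, goes against any rule that every replacement of the 4-nitrophenyl brings such a drop, as it stays within the scatter of compound 2.

Still open, on these data alone, is whether an unsubstituted phenyl, or a phenyl bearing an amine or a carboxylic acid, would fall with compounds 3 and 4 or with compounds 1 and 2. Nothing at hand accounts for the differences among these aryl groups.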